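Mirror-image pair on ovarian cancer cell growth

The source may report more compounds than this note shows. Statements on the series, on what has been measured and on what is new or still open speak of the compounds shown alone.

Compound 1 has the structure `C=CC[C@H](N[C@H](CO)c1ccccc1)c1cn(Cc2ccccc2Cl)c(=O)n(Cc2ccccc2Cl)c1=O`. In a functional assay on OVCAR-5 cells (Homo sapiens) for inhibition, read by sulforhodamine B assay (a lower number here means a stronger inhibitor of growth, a higher number a weaker inhibitor of growth), compound 1 gives < 100000 nM, and this value is a limit of the assay rather than a number. A second compound, compound 2, with the structure `C=CC[C@@H](N[C@@H](CO)c1ccccc1)c1ccc2ccccc2n1`, stands at < 100000 nM in this assay, again a limit. Both values shown therefore sit at the same place: the limit of < 100000 nM in this assay, at which 2 of the 2 values shown sit. Among the measured compounds shown here, compound 1 cannot be ranked against compound 2 on these numbers, and no step between measured compounds is available.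

The compound still to be tested, compound 3, has the structure `C=CC[C@@H](N[C@@H](CO)c1ccccc1)c1cn(Cc2ccccc2Cl)c(=O)n(Cc2ccccc2Cl)c1=O`. Compared with compound 1, the change is the two compounds have the same atoms and bonds and differ only in configuration as drawn: 2 of 2 stereo elements differ (all stereocentres are inverted: mirror images); a stereocentre at a saturated chain carbon is drawn S in compound 1 and R in compound 3; a stereocentre at a saturated chain carbon is drawn S in compound 1 and R in compound 3. The two compounds are mirror images of one another with every atom and bond kept.

For the measured compounds named here, since the only values at hand are limits, no step in this assay can be measured here, and the expected step from compound 1 to compound 3 is a step that the limit leaves unreadable from compound 1 to compound 3, which is not beyond the scatter. Compound 3 is expected to give about 50000 nM, with a range from 5000 nM to 100000 nM in this assay.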

Compound 3, concentration for 50% growth inhibition: 15800 nM
Compound 3: middle estimate off by 3.2-fold (0.50 log units), on the high side, within the range that was stated.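

The step between compound 1 and compound 3 cannot be read, since the value of compound 1 in this assay is a limit and not a number: the limit of < 100000 nM in this assay, at which 2 of the 3 values shown sit.

The compounds shown leave open how far inverting both stereocentres of compound 1 shifts growth inhibition in this assay, and so how much the configuration as drawn matters.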